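The compounds below may be only part of what the source reports. "The series", "measured", "known", "first", "only" and "open" are said of these compounds alone.

Measured so far in an ADME assay on MDCKII-LE cells (Canis lupus familiaris) for permeability, with a stated time of 1.5 h; a lower number here means that the compound crosses the layer more slowly, a higher number that the compound crosses the layer faster:

compound 1 `O=C(N1CCC(c2cnn3cccnc23)CC1)N(c1ncccc1Cl)[C@@H]1CCCNC1`: 1.8 10^-6 cm/s
compound 2 `Cc1ccc2c(N3CCN(C(=O)N(c4nccc5ccccc45)[C@@H]4CCCNC4)CC3)noc2c1`: 8.9 10^-6 cm/s
compound 3 `Cc1cccnc1N(C(=O)N1CCC(c2cnn3cccnc23)CC1)[C@@H]1CCCNC1`: 1.8 10^-6 cm/s

Compound 1 stands level with compound 3 at the digits shown, and the two together give the lowest numbers of the three. Compound 2 lies furthest away, with a number higher by a margin that is beyond the scatter. Going by the values given here, only one pair of compounds differs in a single place: no change at the digits printed from compound 1 to compound 3 (within the scatter), where a methyl replaces a chloro on an aromatic carbon, and the read-out does not move within the scatter.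

Compound 4 `O=C(N1CCC(c2ccccc2)CC1)N(c1ncccc1Cl)[C@@H]1CCCNC1` has not yet been measured. It differs from compound 1 in one place:

a group of 6 heavy atoms (6 carbon; one six-membered aromatic ring of carbon only) in place of a group of 9 heavy atoms (6 carbon, 3 nitrogen; one five-membered aromatic ring with 2 hetero atoms, one six-membered aromatic ring with 2 hetero atoms), on a saturated ring carbon

Among the compounds with values here, no measured step tests this kind of change. The step from compound 1 to compound 3 concerned a different place and offers no guide here. Compound 2, which carries no ring of the leaving kind on its saturated ring, gives 8.9 10^-6 cm/s, but it differs from compound 1 in several places at once, so it can only hint that higher numbers are reachable within this series. On that loose footing, compound 4 is expected to give 6 10^-6 cm/s, with a range from 2.5 10^-6 cm/s to 15 10^-6 cm/s. This expectation amounts to a step of a 3.3-fold higher number from compound 1 to compound 4 (0.52 log units; beyond the scatter), which would be upward and beyond the scatter, though with wide uncertainty.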

Compound 4, apparent permeability: 12.8 10^-6 cm/s
Compound 4: middle estimate off by 2.1-fold (0.33 log units), on the low side, within the range that was stated.
By their numbers in this assay, from the lowest: compounds 1 and 3 (each within the scatter of the next); then compounds 2 and 4 (each within the scatter of the next).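

In this assay, putting phenyl in place of the two-ring group of 9 heavy atoms on the saturated ring carbon gives a 7.1-fold higher number from compound 1 to compound 4 (0.85 log units; beyond the scatter), so this position can shift the read-out beyond the scatter. Going by these compounds alone, the only earlier single-place step, at a different position, gave no change at the digits printed from compound 1 to compound 3 (within the scatter) when methyl replaced chloro on an aromatic carbon, and therefore showed no such shift. The new change alters several things at once, going from 9 heavy atoms to 6, from 3 hydrogen-bond acceptors to 0, and from two aromatic rings to one, and nothing at hand shows which of these differences accounts for the step.

A single pyridyl ring at the same place would keep the one six-membered aromatic ring but put a ring nitrogen back, and where its number would fall relative to those of compound 1 and compound 4 remains an open question. Going by these compounds, it is also open whether phenyl would bring a step of similar size to the compound with methyl in place of chloro, which would show whether the gain carries over to a second member of the series.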